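Dropping the Chloro Group from a Compound at the Limit

A few compounds are considered here, and "the series" means these few. Any claim that something is new, unique, unknown or untested is made for them only; others in the source may bear on it.

Compound 1 `CCN(CC)CCCn1c(=O)c(=Cc2ccc(F)cc2F)s/c1=C1\C(=O)Nc2ccc(Cl)cc21` was tested in a functional assay on MDA-MB-231 cells (Homo sapiens) for inhibition, read by MTT assay, with a stated time of 72 h; a higher number here means a weaker inhibitor, a lower number a stronger inhibitor. In this assay compound 1 gives > 200000 nM, which is a limit of the assay and not a measured number. Its companion compound 2 `CCN(CC)CCCn1c(=O)c(=Cc2cc(OC)c(OC)c(OC)c2)s/c1=C1\C(=O)Nc2ccc(Cl)cc21` carries a different ring on the double-bonded chain carbon. In this assay compound 2 gives > 200000 nM, again a limit. Both values sit at the limit of > 200000 nM in this assay, at which 2 of the 2 values shown sit, so the step that the two limits leave unreadable from compound 1 to compound 2 cannot be read in size. The unmeasured compound 3 `CCN(CC)CCCn1c(=O)c(=Cc2ccc(F)cc2F)s/c1=C1\C(=O)Nc2ccccc21` differs from compound 1 by hydrogen in place of chloro on an aromatic carbon. Among the compounds with values here, no measured step touches this change, and the single measured step gives no readable size, so the evidence is thin. Compound 3 is therefore expected to stay at the limit as well, with an estimate of 200000 nM between 50000 nM and 500000 nM. The expected step of a number no higher from compound 1 to compound 3 (the limit leaves the size open) is thus no change beyond the scatter.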

Compound 3, half-maximal inhibitory concentration: > 200000 nM
Compound 3: a limit, no number; the forecaster's own chance of this, stated with the estimate: 80%; the middle value lies on the limit itself.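

In this assay compound 3 gives > 200000 nM, a limit and not a number. Compound 1 also sits at a limit, so the size of the step between compound 1 and compound 3 cannot be read: the limit of > 200000 nM in this assay, at which 3 of the 3 values shown sit.

The compounds shown leave open whether hydrogen in place of chloro changes inhibition at all.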